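The source may hold more compounds than are shown below. What is called first, only, known or untested is meant among the compounds shown, and "the series" means these compounds.

Compound 1 `CCCOc1c(-c2cc(OC)c(OC)c(OC)c2)oc2ccccc2c1=O` was tested in a functional assay on PC-3 cells (Homo sapiens) for antiproliferative activity, read by WST assay, with a stated time of 3 days (a lower number here means a stronger inhibitor, a higher number a weaker inhibitor), where compound 1 gives 11800 nM. Among the three compounds measured, compound 1 stands second highest: compound 2 `CCN(CC)CCCCOc1c(-c2cc(OC)c(OC)c(OC)c2)oc2ccccc2c1=O` gives 13700 nM, and compound 3 `CCCCCN(CCCCC)CCCOc1c(-c2cc(OC)c(OC)c(OC)c2)oc2ccccc2c1=O` gives 5800 nM. The step from compound 1 to compound 2 is a 1.2-fold higher number from compound 1 to compound 2 (0.06 log units; within the scatter), while the step from compound 1 to compound 3 is a 2.0-fold lower number from compound 1 to compound 3 (0.31 log units; beyond the scatter), and between the two amine-bearing compounds the step is a 2.4-fold lower number from compound 2 to compound 3 (0.37 log units; beyond the scatter). Compound 4 `CCCCCN(CCCCC)CCCCOc1c(-c2cc(OC)c(OC)c(OC)c2)oc2ccccc2c1=O` has not yet been measured. It differs from compound 1 in one place: (dipentylamino)methyl in place of hydrogen on a saturated chain carbon, three bonds along the chain from an oxygen on an aromatic ring. The closest guide is compound 3, whose dipentylamino group at the same place gave a 2.0-fold lower number from compound 1 to compound 3 (0.31 log units; beyond the scatter); the (diethylamino)methyl group of compound 2 gave only a 1.2-fold higher number from compound 1 to compound 2 (0.06 log units; within the scatter). Because compound 3 showed a 2.0-fold lower number from compound 1 to compound 3 (0.31 log units; beyond the scatter), the expected step is a 2.0-fold lower number from compound 1 to compound 4 (0.29 log units; within the scatter), a modest lowering. Compound 4 is estimated at 6000 nM, within a range from 3000 nM to 12000 nM.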

Compound 4, half-maximal inhibitory concentration: 7900 nM
For compound 4 the middle estimate is 1.3-fold (0.12 log units) below the measured one; the measured number falls inside the stated range.
By their numbers in this assay, from the lowest: compounds 3, 4, 1 and 2 (each within the scatter of the next, the first and the last beyond it).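

In this assay the (dipentylamino)methyl group, with its 12 heavy atoms, gives a 1.5-fold lower number from compound 1 to compound 4 (0.17 log units; within the scatter) and so leaves compound 4 not separated from the unsubstituted chain of compound 1, even though compound 3 did separate from it. Compounds 2 and 3 differed in both the amine and the chain length, whereas compounds 2 and 4 differ only in the amine: dipentylamino in place of diethylamino gives a 1.7-fold lower number from compound 2 to compound 4 (0.24 log units; within the scatter) and so shows no clear effect of the longer alkyl groups on nitrogen at this chain length. With dipentylamino kept, (dipentylamino)methyl in place of dipentylamino gives a 1.4-fold higher number from compound 3 to compound 4 (0.13 log units; within the scatter) and so this one-carbon change in chain length also cannot be told apart from scatter.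

Going by these compounds, whether a ring amine such as piperidine or morpholine, or a carboxylic acid, at the end of the chain would move the number further remains open. Nothing measured here explains any of these numbers.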